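This account rests on a few compounds, and the source may have more. Where it says the series, first, only, none or still open, it means among the compounds named here.

Series notes on the agonist set. Going by the values given here, compound 1 `Cc1nc(-c2ccc(C(F)(F)F)cc2)sc1CNc1ccc(CCCC(=O)O)cc1` and compound 2 `O=C(O)/C=C/c1ccc(NCc2cccc(Oc3ccccc3)c2)cc1` are the two members measured so far in a functional assay on CHO cells for agonist activity at Free fatty acid receptor 1 (Homo sapiens), read by a luciferase reporter; a lower number here means a smaller maximal response, a higher number a larger maximal response. In this assay compound 1 gives 44%, while compound 2 gives 76%; compound 2 therefore holds the higher of the two numbers, and the gap between them lies beyond the scatter. Compound 3 `O=C(O)[C@@H]1C[C@H]1c1ccc(NCc2cccc(Oc3ccccc3)c2)cc1` is not yet measured. It differs from compound 2 at a single point: 2-carboxycyclopropyl in place of 2-carboxyethenyl on an aromatic carbon. Among the compounds with values here, no step between measured compounds covers a change of this kind, so the expectation rests on compound 2 alone, whose 76% serves as the anchor. In this assay the expected step is a number 6 percentage points lower from compound 2 to compound 3 (within the scatter), small and not beyond the scatter in either direction. For compound 3 the estimate in this assay is 70%, with a range from 45% to 95%.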

Compound 3, largest response reached (reported as percent of maximum), in percent of the reference or control that the assay uses: 64%
The estimate for compound 3 lay 6 percentage points above the measured number; the range from low to high includes it.
By their numbers in this assay, from the lowest: compound 1; then compound 3; then compound 2.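

In this assay, going by these compounds alone, the first change at this position, on an aromatic carbon para to a large group, is 2-carboxycyclopropyl in place of 2-carboxyethenyl, and it gives a number 12 percentage points lower from compound 2 to compound 3 (beyond the scatter). The position therefore responds to this exchange, yet the response is reduced rather than lost, with compound 3 still reaching 64% in this assay. No measurement in hand bears on the reason for this modest drop.

Going by these compounds, whether a saturated 2-carboxyethyl chain, carrying neither the double bond nor the three-membered ring, would fall closer to compound 2 or to compound 3 remains open. On these data alone, the response of other stereoisomers of the 2-carboxycyclopropyl group also remains open, as the two defined stereocentres of compound 3 represent a single arrangement.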